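Cytotoxicity notes on the thioether series, step to compound 4

A few compounds are considered here, and "the series" means these few. Any claim that something is new, unique, unknown or untested is made for them only; others in the source may bear on it.

Compound 1 `Cc1cc(N2CC[C@@H](C)[C@@H](N(C)c3ncnc4[nH]ccc34)C2)n2nc(SCC3CC3)nc2n1` carries a (cyclopropylmethyl)sulfanyl group on the shared core. Among the compounds with values here, in a toxicity assay on GES1 cells (Homo sapiens) for inhibition, read by MTT assay, with a stated time of 72 h (on this read-out lower numbers stand for stronger inhibition and higher numbers for weaker inhibition), compound 1 gives 27900 nM, the lowest of the three numbers measured so far. Compound 2 `Cc1cc(N2CC[C@@H](C)[C@@H](N(C)c3ncnc4[nH]ccc34)C2)n2nc(SCCc3ccccc3)nc2n1` gives 66200 nM and compound 3 `Cc1cc(N2CC[C@@H](C)[C@@H](N(C)c3ncnc4[nH]ccc34)C2)n2nc(SCc3cc(Cl)ccc3Cl)nc2n1` gives 87500 nM. Both exchanges of the cyclopropyl gave higher numbers: a 2.4-fold higher number from compound 1 to compound 2 (0.38 log units; beyond the scatter), and a 3.1-fold higher number from compound 1 to compound 3 (0.50 log units; beyond the scatter). Between compound 2 and compound 3 the gap is small, a 1.3-fold higher number from compound 2 to compound 3 (0.12 log units; within the scatter).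

Compound 4 `Cc1cc(N2CC[C@@H](C)[C@@H](N(C)c3ncnc4[nH]ccc34)C2)n2nc(SCc3ccc([N+](=O)[O-])cc3)nc2n1` is not yet measured. It differs from compound 1 by 4-nitrophenyl in place of cyclopropyl on a saturated chain carbon bound to a sulfur. The two measured steps from compound 1, which each put a six-membered aromatic ring of carbon only in place of the cyclopropyl, bear most directly on this change, and both were modest rises in the number. Within the data shown here, no measured step tells how a 4-nitrophenyl compares with a benzyl or a 2,5-dichlorophenyl at this place, so the expectation rests on the shared direction of those two steps rather than on the nitro group itself. A modest higher number, beyond the scatter, is expected: a 2.2-fold higher number from compound 1 to compound 4 (0.35 log units; beyond the scatter). Compound 4 is therefore estimated at 62000 nM, with a range of 28000 nM to 135000 nM.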

Compound 4, half-maximal inhibitory concentration: 36600 nM
Beside the measured number, compound 4's estimate is 1.7-fold (0.23 log units) above it; the measured number falls inside the stated range.
By their numbers in this assay, from the lowest: compounds 1, 4, 2 and 3 (each within the scatter of the next, the first and the last beyond it).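

In this assay, the earlier exchanges of cyclopropyl both ended beyond the scatter, but 4-nitrophenyl on the same saturated chain carbon bound to a sulfur does not separate from cyclopropyl (a 1.3-fold higher number from compound 1 to compound 4 (0.12 log units; within the scatter)), so placing a six-membered aromatic ring of carbon only at this position does not by itself move the number beyond the scatter. The groups on that ring now matter, since 4-nitrophenyl and 2,5-dichlorophenyl are separated beyond the scatter (a 2.4-fold lower number from compound 3 to compound 4 (0.38 log units; beyond the scatter)), the first such separation among the aromatic groups at this position, whereas the change from benzyl to 4-nitrophenyl stays within it (a 1.8-fold lower number from compound 2 to compound 4 (0.26 log units; within the scatter)). No available evidence accounts for these differences.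

The compounds shown do not separate the contribution of the nitro group from that of its place on the ring, and they do not show whether a plain phenyl, a 2-nitrophenyl or a 3-nitrophenyl would stay with compound 4 or move toward compound 3. Also open, from the compounds shown here alone, is how an amine or a carboxylic acid on the ring, or a longer chain to the sulfur, would read here.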